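The source may report more compounds than this note shows. Statements on the series, on what has been measured and on what is new or still open speak of the compounds shown alone.

Compound 2, `CCOC(=O)C1=C(C)N/C(=C/c2cc(C)n(-c3cccc(C(F)(F)F)c3)c2C)C1=O`, is the starting point of this step. In an ADME assay on L6 cells (Rattus norvegicus) for cytotoxicity, read by resazurin assay, with a stated time of 72 h (a higher number here means that more compound is needed for the effect, a lower number that less compound is needed), compound 2 gives 100000 nM. Its two neighbours carry other groups on the same aromatic nitrogen: compound 1, `CCOC(=O)C1=C(C)N/C(=C/c2cc(C)n(-c3ccc(CN(C)C)cc3)c2C)C1=O`, gives 120000 nM in this assay, and compound 3, `CCOC(=O)C1=C(C)N/C(=C/c2cc(C)n(-c3ccc([S+](C)[O-])cc3)c2C)C1=O`, gives 220000 nM. Compound 2 and compound 1 lie within the scatter of each other, as a 1.2-fold lower number from compound 1 to compound 2 (0.08 log units; within the scatter) shows, while a 2.2-fold higher number from compound 2 to compound 3 (0.34 log units; beyond the scatter) is a modest difference, and a 1.8-fold higher number from compound 1 to compound 3 (0.26 log units; within the scatter) again falls inside the scatter.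

The new compound 4, `CCOC(=O)C1=C(C)N/C(=C/c2cc(C)n(-c3ccncc3)c2C)C1=O`, differs from compound 2 in one place: pyridin-4-yl in place of 3-(trifluoromethyl)phenyl on an aromatic nitrogen. Both earlier steps that swapped the group on this aromatic nitrogen stayed small, so in this assay the step of a 1.3-fold higher number from compound 2 to compound 4 (0.11 log units; within the scatter) is expected to be small as well, either within the scatter or at most a modest rise. Compound 4 is therefore estimated to give about 130000 nM in this assay, most likely between 60000 nM and 300000 nM.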

Compound 4, half-maximal effective concentration in the L6 assay: 100000 nM
Estimate against measurement, compound 4: 1.3-fold (0.11 log units) above, and the stated range covers the measured number.
By their numbers in the L6 assay, from the lowest: compounds 2, 4, 1 and 3 (each within the scatter of the next, the first and the last beyond it).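

Putting pyridin-4-yl on this aromatic nitrogen brings a hetero atom into the ring, yet in the L6 assay it shifts nothing beyond the scatter: no change at the digits printed from compound 2 to compound 4 (within the scatter), and a 1.2-fold lower number from compound 1 to compound 4 (0.08 log units; within the scatter). Also in the L6 assay, the only gap around the new group that passes the scatter is a modest one, a 2.2-fold lower number from compound 3 to compound 4 (0.34 log units; beyond the scatter). In a physicochemical assay for solubility, read by nephelometry, measured as kinetic solubility, at pH 2.0 (a higher number here means a more soluble compound, a lower number a less soluble compound), compound 2 gives 1 ug/mL, and compound 4 gives 100 ug/mL. What is new is that a change this quiet in the cell read-out comes with a large difference in another property, since pyridin-4-yl in place of 3-(trifluoromethyl)phenyl moves the physicochemical assay strongly: the measured solubility of compound 2, 1 ug/mL, and of compound 4, 100 ug/mL, a 100-fold higher number (2.00 log units; beyond the scatter)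

The compounds shown leave open where compound 1 and compound 3 would stand in the physicochemical assay. They also leave open whether a carboxylic acid or a primary amine on the ring at this nitrogen would stay as close in the L6 assay.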